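The source may hold more compounds than are shown below. What is called first, only, known or untested is meant among the compounds shown, and "the series" means these compounds.

Three analogues of the shared core carry values in a functional assay on Bel7402/5-FU cells (Homo sapiens) for antiproliferative activity, read by MTT assay, with a stated time of 72 h; on this read-out higher numbers stand for weaker inhibition and lower numbers for stronger inhibition. Compound 1 `COc1cccc(CNCc2c(C(=O)O)n(Cc3ccccc3)c3cc(C(C)C)ccc23)c1` gives 5920 nM, the lowest of the three numbers. Compound 3 `COc1cccc(CNCc2c(C(=O)O)n(Cc3ccc(C)cc3)c3ccccc23)c1`, which carries a 4-methylbenzyl on the core nitrogen and no isopropyl on the core, gives 9330 nM, a figure within the scatter of compound 1, so no order between the two can be read. Compound 2 `COc1ccc(Cn2c(C(=O)O)c(CNCc3cccc(O)c3)c3ccc(C(C)C)cc32)cc1` gives 15200 nM, which lies beyond the scatter above compound 1.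

Compound 4 `COc1cccc(CNCc2c(C(=O)O)n(Cc3ccc(C)cc3)c3cc(C(C)C)ccc23)c1` has not been measured in this assay. Relative to compound 1 the change is methyl in place of hydrogen on an aromatic carbon, read one bond further out as benzyl to 4-methylbenzyl on the core nitrogen. Within the data shown here, no measured pair differs in this one place alone, so the size of the step is not known from the series; compound 3 carries the same 4-methylbenzyl, but on a core without the isopropyl group, and its number sits within the scatter of compound 1. The step of a 1.0-fold higher number from compound 1 to compound 4 (0.01 log units; within the scatter) is therefore expected to be small, with no direction beyond the scatter. Compound 4 is estimated at 6000 nM, within the range 3000 nM to 12000 nM.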

Compound 4, half-maximal inhibitory concentration: 4550 nM
Beside the measured number, compound 4's estimate is 1.3-fold (0.12 log units) above it; the range from low to high includes it.
By their numbers in this assay, from the lowest: compounds 4, 1, 3 and 2 (each within the scatter of the next, the first and the last beyond it).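

In this assay, benzyl to 4-methylbenzyl on the core nitrogen now has a size of its own, a 1.3-fold lower number from compound 1 to compound 4 (0.11 log units; within the scatter), so no order can be read between the two and methyl in place of hydrogen at this place leaves the number within the scatter. Among these compounds, with 4-methylbenzyl held fixed, adding the isopropyl group to the core gives a 2.1-fold lower number from compound 3 to compound 4 (0.31 log units; beyond the scatter), a modest step and the only single-place change that lies beyond the scatter. Nothing at hand gives a reason for either step.

As far as these compounds go, whether isopropyl gives a step of similar size with the plain benzyl on the core nitrogen stays open. Also open, from the compounds shown here alone, is whether a chlorine atom or a methoxy group in place of the methyl would move the number beyond the scatter.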